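This account rests on a few compounds, and the source may have more. Where it says the series, first, only, none or still open, it means among the compounds named here.

Of the compounds shown here, two have been measured in an assay on isolated protein for inhibition of leukotriene B4 receptor 1 (Homo sapiens), tested at 10 uM; on this read-out higher numbers stand for more inhibition at the one concentration tested (going by the name of the read-out) and lower numbers for less inhibition. Compound 1, with the structure `CC(=O)c1cc(CO)c(OCCCCCCC#N)cc1O`, gives 40%. Compound 2, with the structure `CCc1cc(C(C)=O)c(O)cc1OCCCC(C)(C)C(=O)O`, gives 89% in this assay. Of the two numbers, compound 2 stands highest, and the gap between compound 1 and compound 2 is larger than the usual scatter of repeated measurements, so the two are genuinely apart.

Compound 3, with the structure `CCc1cc(C(C)=O)c(O)cc1OCCCCCCC(=O)O`, is not yet measured. It is built from the same atoms as compound 2, joined differently: 3-carboxypropyl in place of 1-carboxy-1-methylethyl on a saturated chain carbon, three bonds along the chain from an oxygen on an aromatic ring. The chain that carries the carboxylic acid is the same length in heavy atoms, but its branching is gone.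

For the measured compounds named here, since no pair of measured compounds differs in exactly this way, there is no measured step to lean on. The expectation is that the step of a number 17 percentage points lower from compound 2 to compound 3 (beyond the scatter) will be a modest fall, though one that might still lie within the scatter. Compound 3 is therefore estimated to give 72% in this assay, with a likely range from 45% to 92%.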

Compound 3, a percentage reported as inhibition, at one concentration (the size of the read-out at that concentration, not a potency): 87%
The estimate for compound 3 lay 15 percentage points below the measured number, and the stated range covers the measured number.
By their numbers in this assay, from the lowest: compound 1; then compounds 3 and 2 (each within the scatter of the next).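

In this assay, for the compounds shown here, putting 3-carboxypropyl in place of 1-carboxy-1-methylethyl on a saturated chain carbon, three bonds along the chain from an oxygen on an aromatic ring, gives a number 2 percentage points lower from compound 2 to compound 3 (within the scatter) and is the first change here that can be read in one place. With the same atoms joined differently, the branched and the straight chain cannot be told apart on this read-out, so at this position, for this one pair, the branching on the chain carrying the carboxylic acid makes no difference that the measurement can resolve. Nothing measured here bears on why the two compounds stand level.

Both numbers come from a single concentration and are not potencies, so a full concentration series could still separate compound 2 from compound 3, even though this one does not. Going by these compounds, it also remains open how the read-out would respond on this same core to a shorter or longer chain, or to an amide or a tetrazole in place of the carboxylic acid.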